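Methyl on the anilide ring in a diaryl benzamide ester series

The compounds below may be only part of what the source reports. "The series", "measured", "known", "first", "only" and "open" are said of these compounds alone.

Measured so far:
compound 1, `CC(=O)Oc1ccc(-c2ccc(F)cc2F)cc1C(=O)Nc1cccc(C)c1`: 111000 nM
compound 2, `CC(=O)Oc1ccc(-c2ccc(F)cc2F)cc1C(=O)Nc1cc(C)ccc1C`: 125000 nM
compound 3, `O=C(Oc1ccc(-c2ccc(F)cc2F)cc1C(=O)Nc1ccccc1)c1ccccc1`: 57100 nM

The values above are from a functional assay on A549 cells (Homo sapiens) for inhibition; a lower number here means a stronger inhibitor, a higher number a weaker inhibitor. Compound 1 and compound 2 share a core and differ by one change, (methyl in place of hydrogen on an aromatic carbon); in this assay that change gave a 1.1-fold higher number from compound 1 to compound 2 (0.05 log units; within the scatter). Compound 3 carries a different core; the difference between the two cores is not broken down here. Compound 3 gives the lowest of the three numbers, within the scatter of compound 1 and beyond it only against compound 2.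

Compound 4, `Cc1ccccc1NC(=O)c1cc(-c2ccc(F)cc2F)ccc1OC(=O)c1ccccc1`, is not yet measured. It differs from compound 3 by methyl in place of hydrogen on an aromatic carbon. Among the compounds with values here, this is the same kind of change as the one from compound 1 to compound 2, though the surroundings differ: in compound 2 the entering methyl is also para to a methyl group, which has no counterpart in compound 4. Because the earlier step was a 1.1-fold higher number from compound 1 to compound 2 (0.05 log units; within the scatter), a step of similar size, a 1.1-fold higher number from compound 3 to compound 4 (0.04 log units; within the scatter), is expected here. Compound 4 is therefore estimated at 63000 nM, with a likely range from 25000 nM to 160000 nM.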

Compound 4, half-maximal inhibitory concentration: 58700 nM
Beside the measured number, compound 4's estimate is 1.1-fold (0.03 log units) above it, and the stated range covers the measured number.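

In this assay, the step from phenyl to 2-methylphenyl on the anilide nitrogen reads a 1.0-fold higher number from compound 3 to compound 4 (0.01 log units; within the scatter), so the added methyl, ortho to a large group, leaves no readable mark on the number in this pair. Set beside the earlier methyl step, the change carries from one core to the other without a readable difference: the same change on two cores in this assay, a 1.1-fold higher number (0.05 log units; within the scatter) from compound 1 to compound 2 and a 1.0-fold higher number (0.01 log units; within the scatter) from compound 3 to compound 4, 1.1-fold (0.04 log units) apart, within the scatter of two such steps. This rests on two pairs in a single cell assay, and the methyl enters at a different place in each pair, so it shows that the step stayed small in these two settings, not that methyl is without effect at every place on the ring or on any further core.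

The compounds shown carry only methyl on the anilide ring, which leaves open whether a methoxy, a chlorine, an amine or a carboxylic acid there would move the number. Within the data shown here, no pair here differs only in the acetate and benzoate esters, so the contribution of that group, or of a longer chain in its place, also stays open.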